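The source may hold more compounds than are shown below. What is called first, only, known or untested is meant among the compounds shown, and "the series" means these compounds.

Compound 2 `Cn1ncc(Cl)c1-c1cc(C(=O)N[C@@H]2CN[C@H](CCn3cncn3)C[C@H]2c2ccc(Cl)c(Cl)c2)oc1Cl` gives 4.47 nM in an assay for inhibition of RAC-alpha serine/threonine-protein kinase (Homo sapiens), read by HTRF, with a stated time of 1 h (a lower number here means a stronger inhibitor, a higher number a weaker inhibitor), the top of the three numbers in hand, though its gaps to compound 1 `Cn1ncc(Cl)c1-c1cc(C(=O)N[C@@H]2CN[C@H](CCNS(C)(=O)=O)C[C@H]2c2ccc(F)c(F)c2)oc1Cl`, which gives 3.29 nM, and to compound 3 `CC(=O)NCC[C@@H]1C[C@@H](c2ccc(F)c(F)c2)[C@H](NC(=O)c2cc(-c3c(Cl)cnn3C)c(Cl)o2)CN1`, which gives 2.49 nM, both stay within the scatter. Compound 4 `Cn1ncc(Cl)c1-c1cc(C(=O)N[C@@H]2CN[C@H](CC(=O)NCCO)C[C@H]2c2ccc(Cl)c(Cl)c2)oc1Cl` differs from compound 2 by (2-hydroxyethyl)carbamoyl in place of (1H-1,2,4-triazol-1-yl)methyl on a saturated chain carbon bound to a saturated ring carbon. Among the compounds with values here, the only step that bears on this change is a 1.3-fold lower number from compound 1 to compound 3 (0.12 log units; within the scatter), a swap of one group for another on that chain that stayed within the scatter. With that precedent, no step beyond the scatter is expected in this assay in either direction. Compound 4 is therefore estimated at 4.5 nM, between 2 nM and 10 nM, an expected step of a 1.0-fold higher number from compound 2 to compound 4 (0.00 log units; within the scatter).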

Compound 4, half-maximal inhibitory concentration: 1.41 nM
The estimate for compound 4 lay 3.2-fold (0.50 log units) above the measured number, outside the stated range (below it).
By their numbers in this assay, from the lowest: compounds 4, 3, 1 and 2 (each within the scatter of the next, the first and the last beyond it).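

In this assay, this chain position proved able to move the number beyond the scatter, with a 3.2-fold lower number from compound 2 to compound 4 (0.50 log units; beyond the scatter) when (2-hydroxyethyl)carbamoyl replaced (1H-1,2,4-triazol-1-yl)methyl. The earlier step on this chain, a 1.3-fold lower number from compound 1 to compound 3 (0.12 log units; within the scatter), had stayed within the scatter. No available evidence explains the shift. The compounds shown leave open whether the hydroxyl or the amide carbonyl of the new group accounts for the step, and how a carboxylic acid or a primary amine on this chain would compare.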